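Cyclopropyl for methyl on the fused benzene of compound 2

A few compounds are considered here, and "the series" means these few. Any claim that something is new, unique, unknown or untested is made for them only; others in the source may bear on it.

Measured so far:
compound 1 `O=C(Nc1cccc2[nH]ncc12)NC1CCc2ccccc21` 151 nM
compound 2 `Cc1cccc2c1CCC2NC(=O)Nc1cccc2[nH]ncc12` 46 nM

In an assay on isolated protein for inhibition of transient receptor potential cation channel subfamily V member 1 (Homo sapiens), read by calcium flux (on this read-out higher numbers stand for weaker inhibition and lower numbers for stronger inhibition), compound 2 stands lowest of the two numbers, its nearest neighbour being compound 1 151 nM. For the measured compounds named here, the one step measured, a 3.3-fold lower number from compound 1 to compound 2 (0.52 log units; beyond the scatter), concerns a methyl entering an aromatic carbon. Compound 3 `O=C(Nc1cccc2[nH]ncc12)NC1CCc2c(C3CC3)cccc21` carries cyclopropyl in place of methyl on an aromatic carbon. Going by the values given here, no measured step covers an exchange of methyl for cyclopropyl, so the direction is uncertain; the expectation is a small change, a 1.2-fold lower number from compound 2 to compound 3 (0.06 log units; within the scatter), not clearly beyond the scatter. Compound 3 is therefore estimated at 40 nM, within 12 nM to 130 nM.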

Compound 3, half-maximal inhibitory concentration: 5 nM
Compound 3: the middle estimate sits 8.0-fold (0.90 log units) above what was measured; the whole stated range lies above it.
By their numbers in this assay, from the lowest: compound 3; then compound 2; then compound 1.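

Replacing methyl with cyclopropyl on this aromatic carbon gives a 9.2-fold lower number from compound 2 to compound 3 (0.96 log units; beyond the scatter) in this assay, so the position rewards more than the single methyl tried first. Measured against hydrogen, cyclopropyl gives a 30-fold lower number from compound 1 to compound 3 (1.48 log units; beyond the scatter) at this same place, and across these three compounds the number falls as the group grows, with none going against that order. The data offer no evidence on why cyclopropyl has this effect. Going by these compounds, whether the ring itself matters or only the added carbons remains open, which isopropyl or cyclobutyl here could separate. A methoxy group or an amine at this carbon is also untested among the compounds shown.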